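Cyclising the Amine: Diethylamino to Pyrrolidinyl

The compounds below may be only part of what the source reports. "The series", "measured", "known", "first", "only" and "open" are said of these compounds alone.

The three compounds measured so far in a functional assay on the whole organism (strain Wistar) for inhibition, with Rattus norvegicus as the target, read by paw edema, with stated times of 30 min and 3 h, at a dose of 50 mg/kg by the oral route (on this read-out higher numbers stand for a stronger effect at the one dose given and lower numbers for a weaker effect), are:

compound 1, `CCCNc1cnn(C)c(=O)c1OCC`, which gives 8%
compound 2, `CCOc1c(N(C)C)cnn(C)c1=O`, which gives 30.7%
compound 3, `CCOc1c(N(CC)CC)cnn(C)c1=O`, which gives 1.7%

Compound 3 stands lowest of the three numbers in this assay. Its nearest neighbour is compound 1, a step of a number 6.3 percentage points lower from compound 1 to compound 3 (within the scatter), which is within the scatter, so the two cannot be ordered. Its furthest is compound 2, with a number 29 percentage points lower from compound 2 to compound 3 (beyond the scatter), a modest drop beyond the scatter. The other measured step, a number 22.7 percentage points higher from compound 1 to compound 2 (beyond the scatter), is a modest rise.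

Compound 4, `CCOc1c(N2CCCC2)cnn(C)c1=O`, has not yet been measured. It differs from compound 3 in one place: pyrrolidin-1-yl in place of diethylamino on an aromatic carbon

The step that bears most on this change is a number 29 percentage points lower from compound 2 to compound 3 (beyond the scatter), since both it and the new step alter the same amine substituent, and a number 6.3 percentage points lower from compound 1 to compound 3 (within the scatter), which shows that a differently shaped amine of similar size gave no change beyond the scatter. On these, a step from compound 3 to compound 4 of a number 8.3 percentage points higher from compound 3 to compound 4 (within the scatter) is expected, within the scatter or at most a slight rise. Compound 4 is therefore estimated to give 10% in this assay, with a range from 0% to 30%.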

Compound 4, a percentage reported as inhibition, in the whole organism at one dose (the size of the read-out at that dose, not a potency): -2.3%
Estimate against measurement, compound 4: 12.3 percentage points above; the whole stated range lies above it.
By their numbers in this assay, from the lowest: compounds 4, 3 and 1 (each within the scatter of the next, the first and the last beyond it); then compound 2.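

In this assay, closing the two ethyl arms of diethylamino into pyrrolidin-1-yl keeps the same count of heavy atoms and hydrogen-bond acceptors and gives a number 4 percentage points lower from compound 3 to compound 4 (within the scatter), so at this aromatic carbon the ring alone does not separate the two amines. The dimethylamino group of compound 2 stands apart from the closed amine as it did from the open one, with a number 33 percentage points lower from compound 2 to compound 4 (beyond the scatter), which makes compound 2 the only one of the four set off from all the others. Compound 4 also shows a separation from the propylamino group that compound 3 did not, with a number 10.3 percentage points lower from compound 1 to compound 4 (beyond the scatter), although compound 3 and compound 4 themselves cannot be ordered. Nothing available gives a reason for any of these differences.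

Still open, on these data alone, is whether the four-membered azetidin-1-yl ring, which would be the closed counterpart nearest to dimethylamino, or a morpholin-4-yl ring, with an oxygen in place of a ring carbon, would behave like dimethylamino or like pyrrolidin-1-yl. The unsubstituted amino group and the methylamino group also lie outside this set, so the compounds shown do not tell how far the effect of dimethylamino extends toward smaller amines at this position.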